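Methoxy for Methyl on a Shared Core

The source may report more compounds than this note shows. Statements on the series, on what has been measured and on what is new or still open speak of the compounds shown alone.

Compound 1 `COc1ccc(C2=NN(C3=NC(c4ccccc4)CS3)C(c3cccc4ccccc34)C2)cc1` gives 8740 nM in a functional assay on HepG2 cells (Homo sapiens) for inhibition, read by CCK-8 assay, with a stated time of 48 h; on this read-out higher numbers stand for weaker inhibition and lower numbers for stronger inhibition.
Compound 2 `Cc1ccc(C2=NN(C3=NC(c4ccccc4)CS3)C(c3cccc4ccccc34)C2)cc1` gives 10400 nM in this assay.
Compound 3 `Cc1ccc(C2=NN(C3=NC(=O)CS3)C(c3cccc4ccccc34)C2)cc1` gives 8660 nM in this assay.

Compound 1 differs from compound 2 by methoxy in place of methyl on an aromatic carbon, and that change produced a 1.2-fold lower number from compound 2 to compound 1 (0.08 log units; within the scatter). Compound 3 differs from compound 2 by a group of 6 heavy atoms (3 carbon, 1 nitrogen, 1 oxygen, 1 sulfur; one five-membered non-aromatic ring with 2 hetero atoms) in place of a group of 11 heavy atoms (9 carbon, 1 nitrogen, 1 sulfur; one five-membered non-aromatic ring with 2 hetero atoms, one six-membered aromatic ring of carbon only), on an amine nitrogen in a ring, which produced a 1.2-fold lower number from compound 2 to compound 3 (0.08 log units; within the scatter). All three values lie within the usual scatter of one another.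

Compound 4 `COc1ccc(C2=NN(C3=NC(=O)CS3)C(c3cccc4ccccc34)C2)cc1` has not been measured. It differs from compound 3 by methoxy in place of methyl on an aromatic carbon, the same change made from compound 2 to compound 1, at the same place. Since that earlier change gave a 1.2-fold lower number from compound 2 to compound 1 (0.08 log units; within the scatter), the step is expected to be small, and the estimate for compound 4 is a 1.2-fold lower number from compound 3 to compound 4 (0.06 log units; within the scatter). Compound 4 is therefore expected to give 7500 nM, with a range from 4000 nM to 15000 nM, because the same change gave a 1.2-fold lower number from compound 2 to compound 1 (0.08 log units; within the scatter) before.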

Compound 4, half-maximal inhibitory concentration: 7850 nM
Beside the measured number, compound 4's estimate is 1.0-fold (0.02 log units) below it, within the range that was stated.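

In this assay, methoxy in place of methyl gave a 1.1-fold lower number from compound 3 to compound 4 (0.04 log units; within the scatter), in line with the same change made earlier on the other core: the same change on two cores in this assay, a 1.2-fold lower number (0.08 log units; within the scatter) from compound 2 to compound 1 and a 1.1-fold lower number (0.04 log units; within the scatter) from compound 3 to compound 4, 1.1-fold (0.03 log units) apart, within the scatter of two such steps. The exchange of the group on the amine nitrogen in a ring gave a 1.1-fold lower number from compound 1 to compound 4 (0.05 log units; within the scatter), which likewise agrees with its earlier counterpart: the same change on two cores in this assay, a 1.2-fold lower number (0.08 log units; within the scatter) from compound 2 to compound 3 and a 1.1-fold lower number (0.05 log units; within the scatter) from compound 1 to compound 4, 1.1-fold (0.03 log units) apart, within the scatter of two such steps. Among the compounds shown here, every one of these steps lies within the scatter, so the agreement shows only that neither change moved the number measurably on either core; it does not show that a real effect carries from one core to the other.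

The compounds shown leave open whether a different group in that place, such as an amine, a carboxylic acid or a longer chain, would shift the number beyond the scatter on either core.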